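Methyl to hydrogen on a thiadiazole-linked aminothiophene scaffold

A few compounds are considered here, and "the series" means these few. Any claim that something is new, unique, unknown or untested is made for them only; others in the source may bear on it.

Compound 1 `COc1ccc(C(=O)NNC(=S)Nc2csc(-c3ccccc3)c2)cc1` and compound 2 `O=C(NNC(=S)Nc1csc(-c2ccccc2)c1)c1ccc(O)cc1` share an acylthiosemicarbazide core, while compound 3 `COc1ccc(-c2nnc(Nc3csc(-c4ccccc4)c3)s2)cc1` carries a different core; the difference between the two cores is not broken down here. In a functional assay on B16-F10 cells (Mus musculus) for inhibition, read by colorimetric assay and MTT assay, with a stated time of 72 h (on this read-out higher numbers stand for weaker inhibition and lower numbers for stronger inhibition), compound 1 gives 33000 nM and compound 2 gives 40000 nM, a change of a 1.2-fold higher number from compound 1 to compound 2 (0.08 log units; within the scatter) for the change (hydrogen in place of methyl on an oxygen on an aromatic ring). Compound 3 gives 6000 nM in this assay, the lowest of the three numbers and beyond the scatter from both others. Compound 4 `Oc1ccc(-c2nnc(Nc3csc(-c4ccccc4)c3)s2)cc1` is related to compound 3 by hydrogen in place of methyl on an oxygen on an aromatic ring, the same change seen between compound 1 and compound 2. The step from compound 3 to compound 4 in this assay is expected to be about a 1.2-fold higher number from compound 3 to compound 4 (0.07 log units; within the scatter), resting on the small step of a 1.2-fold higher number from compound 1 to compound 2 (0.08 log units; within the scatter). Compound 4 is therefore estimated at 7000 nM, between 3500 nM and 14000 nM.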

Compound 4, half-maximal inhibitory concentration: 8000 nM
Compound 4: the middle estimate sits 1.1-fold (0.06 log units) below what was measured; the range from low to high includes it.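

Hydrogen in place of methyl on the oxygen gives a 1.3-fold higher number from compound 3 to compound 4 (0.12 log units; within the scatter) in this assay. Across the two cores, the step carries over within what these four compounds can show: the same change on two cores in this assay, a 1.2-fold higher number (0.08 log units; within the scatter) from compound 1 to compound 2 and a 1.3-fold higher number (0.12 log units; within the scatter) from compound 3 to compound 4, 1.1-fold (0.04 log units) apart, within the scatter of two such steps. On both cores, this read-out does not separate methoxy from hydroxy, but two pairs whose steps lie within the scatter cannot show that the change would behave the same way on a further core, nor can they resolve a small real effect.

The compounds shown leave open how an amine, a carboxylic acid or a longer chain such as ethoxy in the same place would read in this assay. They also leave open whether other cell lines would give the same picture.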